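The compounds below may be only part of what the source reports. "The series", "measured", "known", "first", "only" and "open" are said of these compounds alone.

Three compounds share one core and were all tested in a functional assay on the whole organism (strain Kunming) with Mus musculus as the target, with a stated time of 0.5 h, at a dose of 100 mg/kg by the intraperitoneal route; on this read-out higher numbers stand for a weaker effect at the one dose given and lower numbers for a stronger effect. Compound 1, `COc1cc(OC)c(OC)cc1/C=C/COC(=O)/C=C/c1ccc(OC)c(OC)c1OC`, gives 100%. Compound 2, `COc1cc(OC)c(OC)cc1/C=C/COC(=O)/C=C/c1ccc(OC)c(OC)c1`, gives 100%, so that no change at the digits printed from compound 1 to compound 2 (within the scatter). Compound 3, `COc1cc(OC)c(OC)cc1/C=C/COC(=O)/C=C/c1ccc(F)cc1`, gives 100%, and the swap of one whole aryl group, no change at the digits printed from compound 2 to compound 3 (within the scatter), likewise left the read-out where it was. Compound 3 therefore stands level with compound 1 and compound 2 on the numbers seen so far.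

The next compound, compound 4, is `COc1cc(OC)c(OC)cc1/C=C/COC(=O)/C=C/c1ccc(Cl)cc1`. Its difference from compound 3 is chloro in place of fluoro on an aromatic carbon, on an aromatic carbon of a six-membered aromatic ring of carbon only. Among the compounds with values here, no measured step exchanges one halogen for another, so the only guide is that the two steps seen, one removing a methoxy group and one replacing the whole 3,4-dimethoxyphenyl ring by 4-fluorophenyl, both stayed within the scatter. A one-atom change at the same ring is expected to do the same, giving an expected no change at the digits printed from compound 3 to compound 4 (within the scatter). Compound 4 is thus estimated at 100%, between 85% and 100%.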

Compound 4, a percentage reported as activity, at one dose (the size of the read-out at that dose, not a potency): 100%
Compound 4: middle estimate and measured number agree at the digits printed; the measured number falls inside the stated range.
By their numbers in this assay, from the lowest: compounds 1, 2, 3 and 4 (each within the scatter of the next).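

In this assay, the halogen at this ring carbon, para to a large group, can be exchanged with no visible result: chloro in place of fluoro leaves no change at the digits printed from compound 3 to compound 4 (within the scatter) on the read-out. The earlier compounds shown here held no halogen-for-halogen exchange, and this step adds one, while the 4-chlorophenyl group also reads the same as the 3,4-dimethoxyphenyl group, with no change at the digits printed from compound 2 to compound 4 (within the scatter) for that whole-ring replacement. No measurement at hand offers an explanation for this flat result.

With all four compounds level, the values offer no difference that could be tied to any group on this ring. Going by these compounds, whether an amine or a carboxylic acid on this ring, or a longer chain in place of the halogen, would move the read-out stays open.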